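A few compounds are considered here, and "the series" means these few. Any claim that something is new, unique, unknown or untested is made for them only; others in the source may bear on it.

Measured so far in an assay on isolated protein for inhibition of phosphodiesterase 4A (Sus scrofa); on this read-out higher numbers stand for weaker inhibition and lower numbers for stronger inhibition:
compound 1 `COc1ccc(C(=O)Nc2ccccc2C)cc1OC1CCCC1` — 300 nM
compound 2 `COc1ccc(C(=O)Nc2ccccc2O)cc1OC1CCCC1` — 1300 nM
compound 3 `COc1ccc(C(=O)Nc2ccccc2Cl)cc1OC` — 650 nM

Among these three, compound 3 holds the second highest number. Its nearest neighbour is compound 2, whose value lies within the scatter of that of compound 3, so no order between these two can be read. Compound 1 gives a lower number than compound 3, and that gap lies beyond the scatter; since compound 1 and compound 3 differ in more than one place, only what the two values show can be said.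

Compound 4 `COc1ccc(C(=O)Nc2ccccc2Cl)cc1OC(C)=O` arises from compound 3 by one change: acetyl in place of methyl on an oxygen on an aromatic ring, read one bond further out as methoxy to acetoxy. Within the data shown here, the only single-place step measured, a 4.3-fold higher number from compound 1 to compound 2 (0.64 log units; beyond the scatter), concerns hydroxy in place of methyl on an aromatic carbon and therefore does not touch the same place as this change; no measured step alters the group on the oxygen on an aromatic ring. Among the measured compounds shown here, with no precedent, a change in this assay of a 2.0-fold higher number from compound 3 to compound 4 (0.30 log units; within the scatter) is expected, tending toward a higher number. Compound 4 is therefore estimated at 1300 nM, with a range from 400 nM to 4000 nM.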

Compound 4, half-maximal inhibitory concentration: 70000 nM
Compound 4: the middle estimate sits 54-fold (1.73 log units) below what was measured, and the stated range ends below it.
By their numbers in this assay, from the lowest: compound 1; then compounds 3 and 2 (each within the scatter of the next); then compound 4.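

In this assay, among these compounds, the group on the oxygen on an aromatic ring turns out to have a strong bearing on the read-out, which no earlier compound could show. Acetyl in place of methyl at this place gives a 110-fold higher number from compound 3 to compound 4 (2.03 log units; beyond the scatter), a large step toward weaker inhibition from a change that enters only one carbonyl-bearing group in place of a methyl. Nothing available here bears on why the step is so large.

The compounds shown leave open whether this weakening is particular to acetyl or would also appear with other groups on that oxygen, such as ethyl, a longer chain or a methylsulfonyl group. Also open, as far as these compounds go, is whether acetyl would give a step of this size with methyl in place of chloro, the group compound 1 carries there.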